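Thiophene in Place of Bromophenyl: Expected Growth Inhibition

The source may report more compounds than this note shows. Statements on the series, on what has been measured and on what is new or still open speak of the compounds shown alone.

Three measured compounds share one core. Compound 1 `S=C(Nc1ccccc1)N1N=C(c2ccccc2)CC1c1ccc2c(c1)OCCO2` in a functional assay on WM 266-4 cells (Homo sapiens) for antiproliferative activity, read by MTT assay, with a stated time of 48 h (a higher number here means a weaker inhibitor of growth, a lower number a stronger inhibitor of growth), gives 3180 nM. Compound 2 `FC(F)(F)c1ccc(C2=NN(C(=S)Nc3ccccc3)C(c3ccc4c(c3)OCCO4)C2)cc1` in this assay gives 52400 nM, and the step of a 16-fold higher number from compound 1 to compound 2 (1.22 log units; beyond the scatter) is large. Compound 3 `S=C(Nc1ccccc1)N1N=C(c2ccccc2Br)CC1c1ccc2c(c1)OCCO2` carries bromo in place of hydrogen on an aromatic carbon. For compound 3 this assay reports only a limit, > 200000 nM. That limit is the limit of > 200000 nM in this assay, at which 1 of the 3 values shown sits, so compound 3 stands at the weak end of the three, with an at least 62-fold higher number from compound 1 to compound 3 (1.79 log units; beyond the scatter) and an at least 3.8-fold higher number from compound 2 to compound 3 (0.58 log units; beyond the scatter) both beyond the scatter.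

Compound 4 `S=C(Nc1ccccc1)N1N=C(c2cccs2)CC1c1ccc2c(c1)OCCO2` differs from compound 3 by thiophen-2-yl in place of 2-bromophenyl on a carbon with a double bond to nitrogen. For the measured compounds named here, the steps that bear on this change are an at least 3.8-fold higher number from compound 2 to compound 3 (0.58 log units; beyond the scatter), read in reverse, and an at least 62-fold higher number from compound 1 to compound 3 (1.79 log units; beyond the scatter), since compound 4, like compound 1, carries an aromatic ring without a trifluoromethyl or bromo substituent. A large step downward in this assay is therefore expected, an at least 40-fold lower number from compound 3 to compound 4 (1.60 log units; beyond the scatter), bringing compound 4 nearer to compound 1 than to compound 3. Compound 4 is estimated at 5000 nM, within a range from 1500 nM to 40000 nM.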

Compound 4, concentration for 50% growth inhibition: 154000 nM
Compound 4: the middle estimate sits 31-fold (1.49 log units) below what was measured; the whole stated range lies below it.
By their numbers in this assay, from the lowest: compound 1; then compound 2; then compound 4. At a limit, above all of these: compound 3.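

In this assay, the step of a 48-fold higher number from compound 1 to compound 4 (1.69 log units; beyond the scatter) shows that thiophen-2-yl on a carbon with a double bond to nitrogen does not keep the level of phenyl, so a ring without a bromo or trifluoromethyl substituent can still give a high number here. The step of a 2.9-fold higher number from compound 2 to compound 4 (0.47 log units; beyond the scatter) places thiophen-2-yl beyond 4-(trifluoromethyl)phenyl as well, leaving the phenyl of compound 1 with the lowest number of the measured compounds. The step of an at least 1.2-fold lower number from compound 3 to compound 4 (0.11 log units; that floor lies within the scatter) gives only a floor, and the value for compound 3 is a limit, not a number: the limit of > 200000 nM in this assay, at which 1 of the 4 values shown sits.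

On these data alone, how far compound 4 truly lies from compound 3 stays open. So does whether an amine or a carboxylic acid on the phenyl ring at this position would keep the number near that of compound 1.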